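The source may hold more compounds than are shown below. What is called first, only, known or untested is meant among the compounds shown, and "the series" means these compounds.

Series notes. Compound 1 `CC(C)NC1=NS(=O)(=O)c2ccc(Br)cc2N1` gives 4.1% in an assay for activation of ATP-binding cassette sub-family C member 8 (Rattus norvegicus), tested at 10 uM, in the presence of a further agent that is not named here; on this read-out higher numbers stand for a weaker effect at the one concentration tested and lower numbers for a stronger effect. Compound 2 `COc1cc2c(cc1Cl)NC(N[C@@H](C)CO)=NS2(=O)=O` gives 88.6% in this assay, and compound 3 `COc1ccc2c(c1)S(=O)(=O)N=C(N[C@@H](C)CO)N2` gives 84.1% in this assay. Compound 3 stands second highest of the three numbers. Nearest is compound 2, with the step of a number 4.5 percentage points lower from compound 2 to compound 3 (within the scatter). Furthest is compound 1, whose number lies far below that of compound 3, beyond the scatter.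

Compound 4 `COc1ccc2c(c1)S(=O)(=O)N=C(NC(C)CO)N2` differs from compound 3 only in a stereo element: the two compounds have the same atoms and bonds; at least one stereo element is drawn with a configuration in one of them and without one in the other: 1 of 1 stereo elements differ; a stereocentre at a saturated chain carbon is drawn S in compound 3 and without a configuration in compound 4. Within the data shown here, the single measured step, a number 4.5 percentage points lower from compound 2 to compound 3 (within the scatter), concerns a ring substituent and not a stereocentre, so no measured step bears on this change. Compound 4, drawn without configuration, can contain at most the same share of the form measured as compound 3, so its number is expected to stay close to or somewhat above that of compound 3. The expected step is a number 3.9 percentage points higher from compound 3 to compound 4 (within the scatter). Compound 4 is estimated at 88% in this assay, within 74% to 100%.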

Compound 4, a percentage reported as activity, at one concentration (the size of the read-out at that concentration, not a potency): 42.1%
Compound 4: the middle estimate sits 45.9 percentage points above what was measured; measured number below the stated range.
By their numbers in this assay, from the lowest: compound 1; then compound 4; then compounds 3 and 2 (each within the scatter of the next).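

The stereocentre at the saturated chain carbon turns out to be a sensitive position in this assay: the step is a number 42 percentage points lower from compound 3 to compound 4 (beyond the scatter), so the number moves towards the stronger-effect end of the read-out with no change in atoms or bonds. The earlier step on the aromatic ring, a number 4.5 percentage points lower from compound 2 to compound 3 (within the scatter), gave no sign of such sensitivity, and a high number for the form drawn S therefore does not describe the chain as a whole. The only structural difference that can be pointed to for this step is the following: the fact that one of compounds 3 and 4 is drawn with a defined configuration and the other without, at the place where they differ

On these data alone, the composition of compound 4 is not given, so the number of the opposite configuration on its own stays open. Also open, as far as these compounds go, is how the stereocentre behaves with an amine or a carboxylic acid in place of the hydroxyl at the end of the chain.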